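Shortening a Chain on Two Different Cores

The source may hold more compounds than are shown below. What is called first, only, known or untested is meant among the compounds shown, and "the series" means these compounds.

Compound 1 `CCCCCSc1nc(NCc2ccc([Se]C)cc2)c2ccccc2n1`: in a functional assay on CCRF-CEM cells (Homo sapiens) for cytotoxicity, read by MTT assay, with a stated time of 72 h (on this read-out higher numbers stand for weaker inhibition of growth and lower numbers for stronger inhibition of growth), compound 1 gives only a limit, > 100000 nM.
Compound 2 `CSc1nc(NCc2ccc([Se]C)cc2)c2ccccc2n1`: in this assay compound 2 also gives only a limit, > 100000 nM.
Compound 3 `CCCCC[Se]c1nc(N)c2cccnc2n1`: in this assay compound 3 gives 42800 nM.

The change from compound 1 to compound 2 is hydrogen in place of butyl on a saturated chain carbon bound to a sulfur. Its step, a step that the two limits leave unreadable from compound 1 to compound 2, has no readable size because both values sit at the limit of > 100000 nM in this assay, at which 2 of the 3 values shown sit. Compound 4 `C[Se]c1nc(N)c2cccnc2n1` has not yet been measured. It differs from compound 3 by hydrogen in place of butyl on a saturated chain carbon bound to a selenium atom, the same kind of change as in the measured pair, though the place differs: there the chain carbon was bound to a sulfur, here it is bound to a selenium atom. The difference between the two cores is not broken down here. With no size to carry over, the expectation for compound 4 rests on compound 3 alone, which gives 42800 nM in this assay. Compound 4 is expected to lie close to compound 3, an estimated step of a 1.4-fold higher number from compound 3 to compound 4 (0.15 log units; within the scatter). The estimate for compound 4 is 60000 nM, between 20000 nM and 150000 nM.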

Compound 4, concentration for total growth inhibition: > 100000 nM
Compound 4: no number, only a limit; the forecaster's own chance of this, stated with the estimate: 40%; middle value at least 1.6-fold (0.22 log units) from the limit.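

In this assay, cutting pentyl to methyl on the chain bound to a selenium atom gives an at least 2.3-fold higher number from compound 3 to compound 4 (0.36 log units; beyond the scatter), which means weaker inhibition of growth. That size is only a floor, as the value for compound 4 is a limit and not a number. Whether the change acts alike on the two cores cannot be read, because the step on the chain bound to a sulfur has no size: the limit of > 100000 nM in this assay, at which 3 of the 4 values shown sit.

The compounds shown leave open whether a propyl chain on the selenium atom would retain the growth inhibition of compound 3. They also leave open how an amine at the end of the pentyl chain would read in this assay.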